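Sulfonamide in Place of Amide on the Shared Core

This account rests on a few compounds, and the source may have more. Where it says the series, first, only, none or still open, it means among the compounds named here.

Compound 1 `O=C(Nc1cccc(/C=C/C(=O)c2nc3ccccc3[nH]2)c1)c1ccccc1`: 2440 nM
Compound 2 `O=C(Nc1cccc(/C=C/C(=O)c2nc3ccccc3[nH]2)c1)c1ccc(Br)cc1`: 2230 nM
Compound 3 `O=C(/C=C/c1cccc(NS(=O)(=O)c2cccc(Cl)c2)c1)c1nc2ccccc2[nH]1`: 737 nM

These three compounds were tested in a functional assay on HCT-116 cells (Homo sapiens) for antiproliferative activity, read by MTT assay, with a stated time of 48 h; a lower number here means a stronger inhibitor, a higher number a weaker inhibitor. Compound 2 gives the second highest of the three numbers, with compound 1 nearest (a 1.1-fold lower number from compound 1 to compound 2 (0.04 log units; within the scatter)) and compound 3 furthest (a 3.0-fold lower number from compound 2 to compound 3 (0.48 log units; beyond the scatter)). Compound 4 `Cc1cccc(S(=O)(=O)Nc2cccc(/C=C/C(=O)c3nc4ccccc4[nH]3)c2)c1` is not yet measured. It differs from compound 2 in one place: (3-methylphenyl)sulfonyl in place of (4-bromophenyl)carbonyl on a nitrogen on an aromatic ring. Going by the values given here, the step that bears on it is the one from compound 2 to compound 3, where a sulfonyl group replaced the carbonyl group and the number fell by a 3.0-fold lower number from compound 2 to compound 3 (0.48 log units; beyond the scatter); the step from compound 1 to compound 3 is of the same kind (a 3.3-fold lower number from compound 1 to compound 3 (0.52 log units; beyond the scatter)). A modest drop of similar size is therefore expected, so that compound 4 is estimated at 800 nM (range 400 nM to 1600 nM), that is, an expected step of a 2.8-fold lower number from compound 2 to compound 4 (0.45 log units; beyond the scatter).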

Compound 4, half-maximal inhibitory concentration: 597 nM
Estimate against measurement, compound 4: 1.3-fold (0.13 log units) above; the measured number falls inside the stated range.
By their numbers in this assay, from the lowest: compounds 4 and 3 (each within the scatter of the next); then compounds 2 and 1 (each within the scatter of the next).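

The drop on moving to a sulfonyl group no longer rests on compound 3 alone, since (3-methylphenyl)sulfonyl also gives modest steps from both amides (a 3.7-fold lower number from compound 2 to compound 4 (0.57 log units; beyond the scatter); a 4.1-fold lower number from compound 1 to compound 4 (0.61 log units; beyond the scatter)). Within the sulfonyl pair, methyl in place of chloro makes no readable difference in this assay (a 1.2-fold lower number from compound 3 to compound 4 (0.09 log units; within the scatter)). Two different substituents on the sulfonyl aryl ring thus give values within the scatter of each other.

From the compounds shown here alone, whether an amine or a carboxylic acid on that ring would keep this level remains open. Nothing shown here explains the difference between sulfonyl and carbonyl.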